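Three Limits at the Top and an Unmeasured Fourth

The compounds below may be only part of what the source reports. "The series", "measured", "known", "first", "only" and "open" are said of these compounds alone.

Compound 1 `c1ccc2c(c1)CN[C@@H](CN(CCCCNCC1CCOCC1)[C@H]1CCCc3cccnc31)C2`: in a functional assay on cells for agonist activity at C-X-C chemokine receptor type 4 (Homo sapiens), read by fluorescence and calcium flux, with a stated time of 90 s (a lower number here means that less compound is needed, a higher number that more compound is needed for the effect), compound 1 gives > 30000 nM, which is a limit of the assay rather than a number.
Compound 2 `c1ccc2c(c1)CN[C@@H](CN(CCCCNCC1CCSCC1)[C@H]1CCCc3cccnc31)C2`: in this assay compound 2 gives > 30000 nM, again a limit.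
Compound 3 `NCc1cccc(CN(C[C@H]2Cc3ccccc3CN2)[C@H]2CCCc3cccnc32)c1`: in this assay compound 3 gives > 30000 nM, again a limit.

Compound 3 therefore stands nowhere on a scale; it sits at the same limit as the other two, as shown by the limit of > 30000 nM in this assay, at which 3 of the 3 values shown sit. The measured steps bear no readable size: a step that the two limits leave unreadable from compound 1 to compound 2, a step that the two limits leave unreadable from compound 1 to compound 3 and a step that the two limits leave unreadable from compound 2 to compound 3 all run from one limit to another.

Compound 4 `CC(C)(CN)CCN(C[C@H]1Cc2ccccc2CN1)[C@H]1CCCc2cccnc21` differs from compound 3 by 2-(aminomethyl)-2-methylpropyl in place of 3-(aminomethyl)phenyl on a saturated chain carbon bound to an amine nitrogen. All three measured steps bear on this position, since each of them also exchanges the group on the saturated chain carbon bound to the amine nitrogen, yet none of them gives a readable size, so the expected step of a number no higher from compound 3 to compound 4 (the limit leaves the size open) is a guess anchored at the limit. Compound 4 is estimated at 30000 nM, within 8000 nM to 100000 nM, most probably reported as a limit once more.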

Compound 4, half-maximal effective concentration: > 30000 nM
Compound 4 gave a limit, no number; the forecaster's own chance of this, stated with the estimate: 80%; the middle value lies on the limit itself.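

In this assay compound 4 gives > 30000 nM, again a limit. Its steps from compound 1, compound 2 and compound 3 cannot be read, as all four compounds sit at one limit: the limit of > 30000 nM in this assay, at which 4 of the 4 values shown sit.

The compounds shown leave open how much of each compound the effect would take, and so whether exchanging these groups changes it at all.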